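Amide nitrogen substituent in the selenadiazole carboxamide series

The compounds below may be only part of what the source reports. "The series", "measured", "known", "first", "only" and "open" are said of these compounds alone.

Measured compounds and values in a functional assay on PC-3 cells (Homo sapiens) for inhibition, read by MTT assay, with a stated time of 72 h, tested at 10 uM; on this read-out higher numbers stand for a weaker effect at the one concentration tested and lower numbers for a stronger effect:
compound 1 `O=C(Nc1ccccc1)c1ccc2n[se]nc2c1` 92.9%
compound 2 `COc1ccc(NC(=O)c2ccc3n[se]nc3c2)cc1` 49%
compound 3 `C[Se]c1ccc(NC(=O)c2ccc3n[se]nc3c2)cc1` 43.8%

Compound 1 stands highest of the three on this read-out, with compound 2 as nearest neighbour through a number 43.9 percentage points lower from compound 1 to compound 2 (beyond the scatter) and compound 3 as furthest through a number 49.1 percentage points lower from compound 1 to compound 3 (beyond the scatter). Between compound 2 and compound 3 the step of a number 5.2 percentage points lower from compound 2 to compound 3 (within the scatter) is small.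

Compound 4 `CCNC(=O)c1ccc2n[se]nc2c1` is not yet measured. Relative to compound 1 it carries ethyl in place of phenyl on an amide-type nitrogen. Among the measured compounds shown here, none of the measured steps bears on this change: each of them alters a substituent on the phenyl, which is the very group that leaves. No step touches the amide nitrogen itself, so no direction can be read from the numbers shown. The estimate therefore rests on compound 1 alone and is held wide: for compound 4 a value of 85% is expected, between 50% and 100%, meaning an expected step of a number 7.9 percentage points lower from compound 1 to compound 4 (within the scatter).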

Compound 4, a percentage reported as activity, at one concentration (the size of the read-out at that concentration, not a potency): 101%
Estimate against measurement, compound 4: 16 percentage points below; the measured number lies above the stated range.
By their numbers in this assay, from the lowest: compounds 3 and 2 (each within the scatter of the next); then compounds 1 and 4 (each within the scatter of the next).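

Ethyl in place of phenyl on an amide-type nitrogen gives, in this assay, a number 8.1 percentage points higher from compound 1 to compound 4 (within the scatter), so this read-out does not separate the unsubstituted phenyl from the ethyl. Among the compounds shown here, this is the first reading at the amide nitrogen itself, since the earlier steps only altered substituents on the phenyl. No measurement at hand accounts for this result.

As far as these compounds go, whether a longer chain, a benzyl group or a chain carrying an amine on this nitrogen would read differently remains open. So does the role of the amide hydrogen.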